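Swapping an ethyl for a fluorine on the triazole-linked phenyl ring

The compounds below may be only part of what the source reports. "The series", "measured", "known", "first", "only" and "open" are said of these compounds alone.

Of the compounds shown here, two sharing a urea-bearing core have been measured so far. Compound 1 `COc1ccc(-n2cc(COc3cccc(NC(=O)Nc4ccc(Cl)c(C(F)(F)F)c4)c3)nn2)cc1` gives 4680 nM in a functional assay on HepG2 cells (Homo sapiens) for inhibition, read by MTT assay, with a stated time of 72 h; on this read-out higher numbers stand for weaker inhibition and lower numbers for stronger inhibition. Compound 2 `CCc1cccc(-n2cc(COc3cccc(NC(=O)Nc4ccc(Cl)c(C(F)(F)F)c4)c3)nn2)c1` differs from it only on the aromatic nitrogen, carrying a 3-ethylphenyl in place of a 4-methoxyphenyl, and in this assay compound 2 gives 37900 nM. That change produced an 8.1-fold higher number from compound 1 to compound 2 (0.91 log units; beyond the scatter), so compound 2 stands as the highest of the two numbers, the weaker inhibitor of the pair.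

Compound 3 `O=C(Nc1cccc(OCc2cn(-c3cccc(F)c3)nn2)c1)Nc1ccc(Cl)c(C(F)(F)F)c1` is the next step from compound 2. The change is fluoro in place of ethyl on an aromatic carbon, so a smaller group now sits on that ring, meta to a large group. Among the measured compounds shown here, the only measured step, from compound 1 to compound 2, concerned a different substituent in a different position on the same ring, and it was modest. For the measured compounds named here, no measured step shows what exchanging ethyl for fluoro at this position does, so the direction is uncertain; the expectation is a step of a 2.5-fold lower number from compound 2 to compound 3 (0.40 log units; beyond the scatter), likely no larger than the one already seen. Compound 3 is therefore estimated at 15000 nM, with a range from 4000 nM to 60000 nM.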

Compound 3, half-maximal inhibitory concentration: 2120 nM
Estimate against measurement, compound 3: 7.1-fold (0.85 log units) above; the whole stated range lies above it.
By their numbers in this assay, from the lowest: compound 3; then compound 1; then compound 2.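

In this assay, among the compounds shown here, replacing the 3-ethylphenyl with a 3-fluorophenyl gives an 18-fold lower number from compound 2 to compound 3 (1.25 log units; beyond the scatter), a large step where the only earlier one was modest, so the group on this aromatic carbon, meta to a large group, can shift the number a long way even though only one small substituent changes. The 3-fluorophenyl also comes out ahead of the 4-methoxyphenyl, with a 2.2-fold lower number from compound 1 to compound 3 (0.34 log units; beyond the scatter), a modest step but one beyond the scatter, which makes compound 3 the strongest inhibitor of the three. Nothing available here explains why these two groups differ so much at this position.

Ethyl and fluoro are the only two groups shown at this position, so a methyl, a chlorine or an amine there would be needed to tell whether the number moves steadily from group to group or whether ethyl alone stands out. Compound 1 and compound 3 differ in both the group and where it sits on the ring, so the compounds shown cannot say how much of their step comes from each.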